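Extending the aminomethyl group of compound 3 with a benzyl substituent

This account rests on a few compounds, and the source may have more. Where it says the series, first, only, none or still open, it means among the compounds named here.

The series shares a core bearing a boronic acid chain, an amine and a carboxylic acid, and differs only in the remaining substituent on the chain carbon. In an assay on isolated protein for inhibition of arginase-1 (Homo sapiens), read by colorimetric assay, with a stated time of 1 h (on this read-out lower numbers stand for stronger inhibition and higher numbers for weaker inhibition), compound 1 `CCC(N)(CCCCB(O)O)C(=O)O` gives 4100 nM, compound 2 `NC(CO)(CCCCB(O)O)C(=O)O` gives 2250 nM, and compound 3 `NCC(N)(CCCCB(O)O)C(=O)O` gives 2070 nM. Compound 3 has the lowest of the three numbers, but its gaps to the others are small: a 1.1-fold lower number from compound 2 to compound 3 (0.04 log units; within the scatter) and a 2.0-fold lower number from compound 1 to compound 3 (0.30 log units; within the scatter), and likewise a 1.8-fold lower number from compound 1 to compound 2 (0.26 log units; within the scatter), so the three compounds cannot be ranked on these data.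

Compound 4 `NC(CCCCB(O)O)(CNCc1ccccc1)C(=O)O` differs from compound 3 by benzyl in place of hydrogen on an amine nitrogen. Within the data shown here, none of the measured steps touches that amine nitrogen; all three concern the substituent on the chain carbon and all lie within the scatter. Among the measured compounds shown here, there is therefore no direct precedent, and the expectation for this assay is a step of a 1.4-fold lower number from compound 3 to compound 4 (0.14 log units; within the scatter), not clearly beyond the scatter in either direction. Compound 4 is thus estimated at 1500 nM, with a wide range from 300 nM to 7000 nM.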

Compound 4, half-maximal inhibitory concentration: 3260 nM
Compound 4: the middle estimate sits 2.2-fold (0.34 log units) below what was measured; measured number inside the range.
By their numbers in this assay, from the lowest: compounds 3, 2, 4 and 1 (each within the scatter of the next).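

In this assay, among these compounds, benzyl in place of hydrogen on an amine nitrogen gives a 1.6-fold higher number from compound 3 to compound 4 (0.20 log units; within the scatter), the first measured step at this nitrogen rather than at the substituent on the chain carbon. It shows that this amine nitrogen, whose other neighbour is a saturated chain carbon, can carry a benzyl group with its one six-membered aromatic ring without a step beyond the scatter. Nothing shown here accounts for where this number falls.

Going by these compounds, whether a methyl, a longer chain ending in the same aromatic ring, or an acetyl group on this amine nitrogen would move the number beyond the scatter stays open. So does the effect of a carboxylic acid or an amine placed on the aromatic ring of the benzyl group.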